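Swapping an Oxetane Side Group for a Methylcyclobutyl

A few compounds are considered here, and "the series" means these few. Any claim that something is new, unique, unknown or untested is made for them only; others in the source may bear on it.

Of the compounds shown here, three have been measured in a functional assay for agonist activity at Glucose-dependent insulinotropic receptor (Mus musculus), read by cAMP accumulation; a higher number here means a larger maximal response, a lower number a smaller maximal response. Compound 1 `CC1(COC(=O)N2CC3COCC(C2)C3Oc2ncnc(Nc3ccc(C#N)cc3Cl)c2F)COC1` gives 46% in this assay, the lowest of the three numbers. Compound 2 `CC1(OC(=O)N2CC3COCC(C2)C3Oc2ncnc(Nc3ccc(F)cc3F)c2F)CC1`, which carries a different small ring on its carbamate and a different substituted aniline, reaches 73%, a gap above compound 1 that lies beyond the usual scatter. Compound 3 `N#Cc1ccc(Oc2ncnc(OC3C4COCC3CN(c3ncc(F)cn3)C4)c2C2CC2)c(Cl)c1`, built around the same core but with other attachments, reaches 100%, the furthest from compound 1. Compounds 2 and 3 each differ from compound 1 in more than one place, so neither gap can be tied to a single structural change.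

Compound 4 `CC1(OC(=O)N2CC3COCC(C2)C3Oc2ncnc(Nc3ccc(C#N)cc3Cl)c2F)CCC1` has not yet been measured. It differs from compound 1 in one place: 1-methylcyclobutyl in place of (3-methyloxetan-3-yl)methyl on an oxygen next to a carbonyl group. The group that enters has no oxygen and no hydrogen-bond acceptor, where the leaving group had one of each.

For the measured compounds named here, no measured pair shows exactly this step, so the expectation is loose. It rests on compound 2, whose carbamate also carries a small all-carbon ring and which gives 73%, though its aniline differs as well. The step of a number 14 percentage points higher from compound 1 to compound 4 (beyond the scatter) is expected to be a modest rise, near the edge of the scatter. Compound 4 is estimated at 60%, with a likely range from 35% to 88%.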

Compound 4, largest response reached (reported as percent of maximum), in percent of the reference or control that the assay uses: 88%
The estimate for compound 4 lay 28 percentage points below the measured number; the range from low to high includes it.
By their numbers in this assay, from the lowest: compound 1; then compound 2; then compound 4; then compound 3.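

For the compounds shown here, with the substituted aniline and the shared core unchanged, placing 1-methylcyclobutyl in place of (3-methyloxetan-3-yl)methyl on an oxygen next to a carbonyl group gives a number 42 percentage points higher from compound 1 to compound 4 (beyond the scatter) in this assay, the first step in this set that can be tied to one place. Going by these compounds alone, the group on this oxygen therefore has a large bearing on the maximal response, which the earlier compounds could not show, as each differed from compound 1 in more than one place. Nothing measured here explains the rise, so the step records what happened but not the reason for it.

This one swap alters several features together: the ring changes from one holding an oxygen to one of carbon only, the hydrogen-bond acceptor disappears, and the heavy-atom count changes. A (1-methylcyclobutyl)methyl group or a 3-methyloxetan-3-yl group on the same oxygen would help separate these features, while a tert-butyl group would test whether a ring is needed there at all.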